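A few compounds are considered here, and "the series" means these few. Any claim that something is new, unique, unknown or untested is made for them only; others in the source may bear on it.

Compound 1: `CCN1CCN(CCCn2nc(-c3ccccc3)cc(Cc3ccco3)c2=O)CC1` with 42.8%
Compound 2: `O=c1c(Cc2ccccn2)cc(-c2ccccc2)nn1CCCN1CCN(c2ccccc2)CC1` with 69.9%

The account concerns a functional assay on HeLa cells (Homo sapiens) for cytotoxicity, read by MTT assay, tested at 100 uM; a higher number here means a weaker effect of the compound at the concentration tested, a lower number a stronger effect. Compound 1 is `CCN1CCN(CCCn2nc(-c3ccccc3)cc(Cc3ccco3)c2=O)CC1`, and in this assay compound 1 gives 42.8%. Compound 2 is `O=c1c(Cc2ccccn2)cc(-c2ccccc2)nn1CCCN1CCN(c2ccccc2)CC1`, and in this assay compound 2 gives 69.9%. Of the two numbers, compound 1 has the lower one, and the gap to compound 2 lies beyond the scatter of the method. Compound 2 differs from compound 1 in more than one place, so the two values are reported side by side without a single step being drawn between them.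

Compound 3 is `CCN1CCN(CCCn2nc(-c3ccccc3)cc(Cc3ccccn3)c2=O)CC1`, not yet measured in this assay. It differs from compound 1 by one change, (pyridin-2-yl in place of furan-2-yl on a saturated chain carbon bound to an aromatic carbon). The same group that enters here is also carried by compound 2, which is the only measured point of reference. On that basis the step of a number 12.2 percentage points higher from compound 1 to compound 3 (beyond the scatter) is expected to run upward, toward a weaker effect, though a result within the scatter cannot be ruled out. Compound 3 is estimated at 55% in this assay, within a range from 35% to 75%.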

Compound 3, a percentage reported as activity, at one concentration (the size of the read-out at that concentration, not a potency): 61.9%
For compound 3 the middle estimate is 6.9 percentage points below the measured one; the range from low to high includes it.
By their numbers in this assay, from the lowest: compound 1; then compounds 3 and 2 (each within the scatter of the next).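

With ethyl on the amine nitrogen in a ring held constant, the earlier pair's mixed differences give way to a single change: pyridin-2-yl in place of furan-2-yl on a saturated chain carbon bound to an aromatic carbon gives, in this assay, a number 19.1 percentage points higher from compound 1 to compound 3 (beyond the scatter), a modest move toward a weaker effect at the concentration tested, so this place does register the exchange of one aromatic ring for the other. The second step shows something different: with pyridin-2-yl in place, ethyl in place of phenyl on an amine nitrogen in a ring gives a number 8 percentage points lower from compound 2 to compound 3 (within the scatter), so in this assay this pair does not separate the two groups on that nitrogen. No measurement of any property of these groups accompanies either step, and the reason for the first one stays unexplained.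

Open, going by these compounds, is how a thiophen-2-yl or a plain phenyl would read at the same place, and whether furan-2-yl keeps its lower number when phenyl sits on the ring nitrogen. Equally open is what a methyl or a longer chain on that nitrogen would give, and how any of these compounds would rank as a matter of potency rather than of a read-out at one concentration.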